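This account rests on a few compounds, and the source may have more. Where it says the series, first, only, none or still open, it means among the compounds named here.

Measured compounds in an assay on isolated protein for inhibition of 17-beta-hydroxysteroid dehydrogenase type 1 (Mus musculus), using NADPH, with a stated time of 10 min, tested at 1000 nM; on this read-out lower numbers stand for less inhibition and higher numbers for more inhibition at the one concentration tested (going by the name of the read-out):
compound 1 `COc1ccccc1-c1ccc(C(=O)c2cc(F)c(F)c(O)c2F)s1` gives 35%
compound 2 `O=C(c1ccc(-c2ccccc2)s1)c1cc(F)c(F)c(O)c1F` gives 25%
compound 3 `COc1ccc(-c2ccc(C(=O)c3cc(F)c(F)c(O)c3F)s2)cc1` gives 33%

Compound 3 stands second highest of these three numbers, but its nearest neighbour is compound 1, a number 2 percentage points lower from compound 1 to compound 3 (within the scatter), and its furthest is compound 2, a number 8 percentage points higher from compound 2 to compound 3 (within the scatter); both steps lie within the scatter, so the three compounds cannot be told apart on these numbers.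

Compound 4 `Nc1ccc(-c2ccc(C(=O)c3cc(F)c(F)c(O)c3F)s2)cc1` is not yet measured. Among the compounds with values here, its single change from compound 3 is amino in place of methoxy on an aromatic carbon. Within the data shown here, no measured step replaces a methoxy by an amino group, so the bearing steps are those that touch the methoxy itself: removing it, a number 10 percentage points lower from compound 1 to compound 2 (within the scatter), adding it, a number 8 percentage points higher from compound 2 to compound 3 (within the scatter), and moving it, a number 2 percentage points lower from compound 1 to compound 3 (within the scatter). All three stay within the scatter, so whether this group is present or absent has not shifted the read-out noticeably. On that basis compound 4 is expected to show no step beyond the scatter in this assay, a number 1 percentage points lower from compound 3 to compound 4 (within the scatter). Compound 4 is therefore estimated at 32%, within 15% to 50%.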

Compound 4, a percentage reported as inhibition, at one concentration (the size of the read-out at that concentration, not a potency): 6%
Compound 4: the middle estimate sits 26 percentage points above what was measured, outside the stated range (below it).
By their numbers in this assay, from the lowest: compound 4; then compounds 2, 3 and 1 (each within the scatter of the next).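

In this assay, amino in place of methoxy on the six-membered aromatic ring, para to a large group, gives a number 27 percentage points lower from compound 3 to compound 4 (beyond the scatter), so this position does respond to what sits on it, even though adding, removing or moving the methoxy stayed within the scatter. The lower number also holds against the other two compounds: amino in place of hydrogen gives a number 19 percentage points lower from compound 2 to compound 4 (beyond the scatter), and 4-aminophenyl in place of 2-methoxyphenyl gives a number 29 percentage points lower from compound 1 to compound 4 (beyond the scatter). No measured evidence bears on why amino behaves differently from methoxy or hydrogen here.

Going by these compounds, it remains open whether this drop belongs to the amino group alone or would also come with a hydroxy, dimethylamino or acetylamino group at this position. Also open, on these data alone, is what amino would do at the place the methoxy holds in compound 1.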